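This account rests on a few compounds, and the source may have more. Where it says the series, first, only, none or still open, it means among the compounds named here.

Working notes on the series. The shared core carries an amide on a three-carbon chain and an aromatic ring. Compound 3 `CCCC(=O)NCCCc1cccc(OC)c1` stands with the lowest number of the two measured in an assay for binding affinity to melatonin receptor (Gallus gallus) (a lower number here means a stronger inhibitor, a higher number a weaker inhibitor), at 5.5 nM. Among the compounds with values here, compound 2 `COc1cccc(CCCNC(C)=O)c1` gives 63 nM in this assay, and the one measured step, an 11-fold lower number from compound 2 to compound 3 (1.06 log units; beyond the scatter), concerns the chain bound to the carbonyl, not the ring. Compound 1 `CCCCC(=O)NCCCc1ccccc1OC` in this assay gives > 100000 nM, which is a limit of the assay and not a number; this is the limit (the limit of > 100000 nM in this assay, at which 1 of the 3 values shown sits). Compound 1 differs from compound 3 in two places at once, so its value says nothing separable about the ring substituent.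

Compound 4 `CCCC(=O)NCCCc1cccc(Cl)c1` differs from compound 3 by chloro in place of methoxy on an aromatic carbon. Within the data shown here, no measured step bears on an exchange at the ring; the step from compound 2 to compound 3 alters only the chain and gives no guide here. The methoxy that leaves is the one hydrogen-bond acceptor on the ring, and chloro brings none, so a higher number is expected, beyond the scatter but with wide uncertainty. The expected step is a 9.1-fold higher number from compound 3 to compound 4 (0.96 log units; beyond the scatter). For compound 4 the estimate in this assay is 50 nM, within a range from 5 nM to 500 nM.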

Compound 4, inhibition constant: 113 nM
Beside the measured number, compound 4's estimate is 2.3-fold (0.35 log units) below it, and the stated range covers the measured number.
By their numbers in this assay, from the lowest: compound 3; then compounds 2 and 4 (each within the scatter of the next). At a limit, above all of these: compound 1.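

Within the data shown here, the exchange of methoxy for chloro gives a 21-fold higher number from compound 3 to compound 4 (1.31 log units; beyond the scatter), the first reading of a change on the aromatic ring in this assay, and it shows that the group on this aromatic carbon matters to the number and not only the chain bound to the carbonyl. The ring position and that chain now each have one step beyond the scatter, the chain step being an 11-fold lower number from compound 2 to compound 3 (1.06 log units; beyond the scatter), but each rests on a single pair of compounds, so no pattern across the series follows from either. Nothing measured here gives a cause for the ring step, and the swap of a group counted with one hydrogen-bond acceptor for one counted with none cannot be separated from the change in heavy atoms.

From the compounds shown here alone, whether a hydroxyl, an ethoxy or a fluoro on this aromatic carbon would hold the number of compound 3 at 5.5 nM stays open. Also open, going by these compounds, is whether a longer chain bound to the carbonyl would extend the chain step or reverse it, and whether the chloro exchange would give a step of the same size on a different chain.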